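This account rests on a few compounds, and the source may have more. Where it says the series, first, only, none or still open, it means among the compounds named here.

Measured so far:
- compound 1 `Cc1cnc(NC(=O)c2cc(Oc3cnc(C(=O)N(C)C)cn3)c3cc(C)oc3c2)cn1` gives 176000 nM
- compound 2 `Cc1cnc(NC(=O)c2cc(Oc3ccc(S(C)(=O)=O)cc3)c3cn(C)nc3c2)cn1` gives 454000 nM

In a physicochemical assay for solubility, measured as kinetic solubility (a lower number here means a less soluble compound, a higher number a more soluble compound), compound 2 holds the higher of the two numbers, and the gap down to compound 1 lies beyond the usual scatter. Within the data shown here, the two compounds differ in more than one place, so their gap does not isolate any single change, and no measured pair shows a one-place step.

The next compound is compound 3 `Cc1cnc(NC(=O)c2cc(Oc3ccc(S(=O)(=O)C4CC4)cc3)c3cn(C)nc3c2)cn1`, which keeps the core of compound 2 and changes only the sulfonyl substituent: cyclopropyl in place of methyl on a sulfonyl sulfur. In words, this is cyclopropyl in place of methyl on a sulfonyl sulfur, or methylsulfonyl to cyclopropylsulfonyl.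

Among the measured compounds shown here, with no measured precedent for this change, the expectation is only tentative: a modest fall in this assay, possibly not much beyond the scatter. The expected size is a 1.5-fold lower number from compound 2 to compound 3 (0.18 log units; within the scatter) and a rise is not excluded. The estimate for compound 3 is 300000 nM, with an expected range from 130000 nM to 550000 nM.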

Compound 3, solubility: 73000 nM
The estimate for compound 3 lay 4.1-fold (0.61 log units) above the measured number; the whole stated range lies above it.
By their numbers in this assay, from the lowest: compound 3; then compound 1; then compound 2.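

In this assay, among these compounds, the first one-place step gives a 6.2-fold lower number from compound 2 to compound 3 (0.79 log units; beyond the scatter) and lies beyond the usual scatter, so the substituent on a sulfonyl sulfur whose other neighbour is aromatic carbon is a place where this read-out responds to a small edit. With the rest of compound 2 held, cyclopropyl in place of methyl goes from 1 heavy atom to 3 and adds one three-membered non-aromatic ring of carbon only, with no change in hydrogen-bond donors or acceptors, so a change of that kind alone is enough to move the number this far. No measured property of either group bears on this step, and the data offer no explanation for it.

This single step cannot tell whether the ring or the added carbons carry the fall, a question that turns on open chains such as ethyl or isopropyl on the same sulfonyl sulfur. Also open, from the compounds shown here alone, are how an amine on that sulfur would read, and whether the step would hold on the core of compound 1.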